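The source may hold more compounds than are shown below. What is called first, only, known or untested is meant among the compounds shown, and "the series" means these compounds.

Measured so far in a functional assay on CHO cells for antagonist activity at C-C chemokine receptor type 4 (Homo sapiens), read by radioligand binding and GTPgammaS binding; on this read-out higher numbers stand for weaker inhibition and lower numbers for stronger inhibition:
compound 1 `COc1cc2c(cc1NS(=O)(=O)c1cccc(Cl)c1Cl)[nH]c(=O)n2C` gives 200 nM
compound 2 `CCCn1c(=O)[nH]c2cc(NS(=O)(=O)c3cccc(Cl)c3Cl)c(OC)cc21` gives 3980 nM

For the measured compounds named here, compound 2 stands at the higher of the two numbers in this assay, its only neighbour being compound 1, reached by a 20-fold higher number from compound 1 to compound 2 (1.30 log units; beyond the scatter). Compound 3 `COc1cc2c(cc1NS(=O)(=O)c1cccc(Cl)c1Cl)[nH]c(=O)n2CCN(C)C` is not yet measured. It differs from compound 2 by dimethylamino in place of methyl on a saturated chain carbon, two bonds along the chain from an aromatic nitrogen. Going by the values given here, no measured step shows this exact change; the one step on hand, a 20-fold higher number from compound 1 to compound 2 (1.30 log units; beyond the scatter), concerns a longer chain on the aromatic nitrogen and was large, so this region of the shared core is clearly sensitive. Among the compounds with values here, in compound 3 the chain length is kept and a hydrogen-bond acceptor enters at its end, for which no precedent exists here. The expectation for compound 3 is therefore a number near compound 2, with wide uncertainty, expressed as a 1.6-fold lower number from compound 2 to compound 3 (0.20 log units; within the scatter). Compound 3 is estimated at 2500 nM, with a range from 600 nM to 10000 nM.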

Compound 3, half-maximal inhibitory concentration in the C-C chemokine receptor type 4 assay: 2000 nM
Beside the measured number, compound 3's estimate is 1.3-fold (0.10 log units) above it; the measured number falls inside the stated range.
By their numbers in the C-C chemokine receptor type 4 assay, from the lowest: compound 1; then compounds 3 and 2 (each within the scatter of the next).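

In the C-C chemokine receptor type 4 assay, dimethylamino in place of methyl on a saturated chain carbon, two bonds along the chain from an aromatic nitrogen, gives a 2.0-fold lower number from compound 2 to compound 3 (0.30 log units; within the scatter), so this position takes the change without a difference that can be told from the scatter. The dimethylamino end does not close the gap to the smaller compound 1, with a 10-fold higher number from compound 1 to compound 3 (1.00 log units; beyond the scatter), so compound 2 and compound 3 both stay apart from compound 1. In a physicochemical assay for lipophilicity, at pH 7.4 (a lower number here means a more polar compound, a higher number a more lipophilic compound), compound 2 gives 3.2 and compound 3 gives 2.6. While the two stay within the scatter of each other in the C-C chemokine receptor type 4 assay, they part in the physicochemical assay, with compound 3 the more polar: the measured distribution coefficient of compound 2, 3.2, and of compound 3, 2.6, a number 0.60 log units lower (beyond the scatter)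

One pair cannot tie lipophilicity to inhibition in either direction. As far as these compounds go, whether a carboxylic acid, a hydroxyl or a cyclic amine such as morpholine at the chain end would come closer to compound 1 stays open.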